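The source may report more compounds than this note shows. Statements on the series, on what has been measured and on what is new or still open speak of the compounds shown alone.

Compound 1 `CCNc1nc(NCc2ccc(C(=O)N[C@H]3C[C@@H]3c3ccccc3)cc2)c2cc(C)ccc2n1`: 1800 nM
Compound 2 `Cc1ccc2nc(N(C)C)nc(NCc3ccc(C(=O)N[C@H]4C[C@@H]4c4ccccc4)cc3)c2c1`: 2400 nM

In a functional assay on SW480 cells (Homo sapiens) for inhibition, read by luminescence and resazurin assay, with a stated time of 3 days (a higher number here means a weaker inhibitor, a lower number a stronger inhibitor), compound 2 gives 2400 nM and compound 1 gives 1800 nM, so the two stand level. Within the data shown here, the only measured step is a 1.3-fold higher number from compound 1 to compound 2 (0.12 log units; within the scatter), with dimethylamino in place of ethylamino on an aromatic carbon.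

Compound 3 `Cc1ccc2nc(N(C)C)nc(NCc3ccc(C(=O)NCc4ccc(F)cc4)cc3)c2c1` keeps the dimethylamino group of compound 2 and changes the other end of the molecule: 4-fluorobenzyl in place of 2-phenylcyclopropyl on an amide-type nitrogen. In short, 4-fluorobenzyl stands in place of 2-phenylcyclopropyl on an amide-type nitrogen. The measured step lies at a different place, so it says nothing direct about this change. Among the measured compounds shown here, no measured pair varies the group on the amide-type nitrogen. The data therefore give no direction for the change, and the range has to stay wide on both sides. The working expectation is no shift beyond the scatter in this assay. The expected step is small, a 1.3-fold higher number from compound 2 to compound 3 (0.10 log units; within the scatter). Compound 3 is estimated at 3000 nM, with an expected range of 900 nM to 10000 nM.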

Compound 3, half-maximal inhibitory concentration: 1100 nM
Compound 3: the middle estimate sits 2.7-fold (0.44 log units) above what was measured, within the range that was stated.
By their numbers in this assay, from the lowest: compounds 3, 1 and 2 (each within the scatter of the next, the first and the last beyond it).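

Among these compounds, the group on the amide-type nitrogen does bear on the read-out in this assay: 4-fluorobenzyl in place of 2-phenylcyclopropyl gives a 2.2-fold lower number from compound 2 to compound 3 (0.34 log units; beyond the scatter) and so a modest change, whereas the only earlier step, at the amino group on an aromatic carbon, stayed within the scatter. With the dimethylamino group held constant, this pair also shows that inhibition in this range does not depend on the three-membered ring or the two defined stereocentres of 2-phenylcyclopropyl, since compound 3 has neither. No measurement at hand explains why the number falls with this change.

From the compounds shown here alone, it remains open whether the step comes from the fluorine or from the benzyl group itself, a question that plain benzyl would address, while a longer chain such as 2-phenylethyl on the amide-type nitrogen would test the length of the link to the aromatic ring. Also open, going by these compounds, are whether the step carries over to the ethylamino analogue on the shared core and how an amine or a carboxylic acid on the benzyl ring would read in this assay.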